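Swapping a halogen: from compound 1 to compound 3

A few compounds are considered here, and "the series" means these few. Any claim that something is new, unique, unknown or untested is made for them only; others in the source may bear on it.

This study looks at how well mouse macrophage-like cells tolerate a small set of related compounds. In an ADME assay on RAW264.7 cells (Mus musculus) for cytotoxicity, read by MTT assay, with a stated time of 24 h (a higher number here means that more compound is tolerated, a lower number that less compound is tolerated), compound 1, with the structure `O=C1CSC(N2N=C(c3ccc(Cl)c(Cl)c3)CC2c2ccc(Cl)cc2)=N1`, gives 187000 nM. A second compound from the same family, compound 2 with the structure `COc1ccc(C2CC(c3ccc(C)c(C)c3)=NN2C2=NC(=O)CS2)cc1`, gives 387000 nM in this assay. Within the data shown here, of the two numbers known so far, compound 1 stands lowest, and the gap up to compound 2 lies beyond the usual scatter of such measurements. Among the measured compounds shown here, the two compounds differ in several places at once, so their values show only that compound 2 is tolerated at a higher concentration, not which part of the structure is responsible.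

Compound 3, with the structure `O=C1CSC(N2N=C(c3ccc(Cl)c(Cl)c3)CC2c2ccc(Br)cc2)=N1`, has not yet been measured in this assay. It differs from compound 1 in one place only: bromo in place of chloro on an aromatic carbon. For the measured compounds named here, no measured pair in this set shows the effect of exactly this change, so its size cannot be read from the data. Given that the shared core stays untouched, the step of no change at the digits printed from compound 1 to compound 3 (within the scatter) is expected to be small, in no clear direction and within the scatter. Compound 3 is therefore estimated to give 187000 nM in this assay, with a likely range from 90000 nM to 380000 nM.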

Compound 3, half-maximal cytotoxic concentration: 280000 nM
Compound 3: the middle estimate sits 1.5-fold (0.18 log units) below what was measured; the measured number falls inside the stated range.
By their numbers in this assay, from the lowest: compounds 1, 3 and 2 (each within the scatter of the next, the first and the last beyond it).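

In this assay the set now holds its first comparison that changes one place only, and bromo in place of chloro on an aromatic carbon gives a 1.5-fold higher number from compound 1 to compound 3 (0.18 log units; within the scatter) in this comparison. At this position, on a six-membered aromatic ring of carbon only and para to a large group, going from 4-chlorophenyl to 4-bromophenyl therefore leaves the two compounds indistinguishable in this assay, something the earlier pair could not show because compound 1 and compound 2 differ in several places at once. No other measurement in this set bears on why the two halogens read alike.

Whether this position tolerates change more widely stays open, as only two halogens are shown here, and an amine, a carboxylic acid or a longer chain in the same place could behave quite differently. The higher number of compound 2, at 387000 nM, also remains unassigned, since nothing shown separates the contributions of the places in which it differs from compound 1.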